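Fluoro for methoxy in a weakly inhibiting series

The source may hold more compounds than are shown below. What is called first, only, known or untested is meant among the compounds shown, and "the series" means these compounds.

Compound 1 `COc1ccc(Cn2c(N)nc3cc(Cl)c(Cl)cc32)cc1` gives 45000 nM as a number
Compound 2 `COc1ccc(Cn2c(Cl)nc3cc(Cl)c(Cl)cc32)cc1` gives > 100000 nM as a limit
Compound 3 `O=[N+]([O-])c1cccc(Cn2c(Cl)nc3cc(Cl)c(Cl)cc32)c1` gives 239000 nM as a number

In a functional assay on KB cells (Homo sapiens) for inhibition (a lower number here means a stronger inhibitor, a higher number a weaker inhibitor), compound 2 has only a limit (> 100000 nM) and no number. That reading is the limit of > 100000 nM in this assay, at which 1 of the 3 values shown sits, in this small set. In this assay compound 3 reads 239000 nM as a number.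

Compound 4 `Fc1ccc(Cn2c(Cl)nc3cc(Cl)c(Cl)cc32)cc1` is the next to be read. It carries fluoro in place of methoxy on an aromatic carbon, para to a large group (fluoro in place of methoxy on an aromatic carbon) and is otherwise the same as compound 2.

For the measured compounds named here, the one measured step of an at least 2.2-fold higher number from compound 1 to compound 2 (0.34 log units; beyond the scatter) is a change of chloro in place of amino, so it gives no size for this change. Going by the values given here, no measured step touches the methoxy group. The expectation therefore rests on compound 2 and its limit of > 100000 nM alone. No step beyond the scatter is expected in this assay and the estimated step that the limit leaves unreadable from compound 2 to compound 4 has no firm direction. For compound 4 the estimate is 120000 nM with an expected range from 40000 nM to 350000 nM as the likely span.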

Compound 4, half-maximal inhibitory concentration: > 100000 nM
Compound 4: a limit, no number; the forecaster's own chance of this, stated with the estimate: 45%; the middle value lies beyond the limit too.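

In this assay compound 4 gives > 100000 nM, which is a limit. For the compounds shown here, compound 2 gives > 100000 nM, also a limit, and no step for fluoro in place of methoxy can be read between compound 2 and compound 4. The compounds shown leave open whether this change alters the read-out at all, and in which direction.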